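The compounds below may be only part of what the source reports. "The series", "measured", "known", "first", "only" and "open" are said of these compounds alone.

Of the compounds shown here, three built on a shared core have been measured in an ADME assay on BJ cells (Homo sapiens), read by MTT assay, with a stated time of 72 h; a lower number here means a stronger inhibitor, a higher number a weaker inhibitor. Compound 3 `Cc1ncnc2c1c(-c1ccsc1)cn2[C@@H]1O[C@H](CO)[C@@H](O)[C@H]1O` carries a methyl, and in this assay compound 3 gives 96900 nM. Compound 2 `CSc1ncnc2c1c(-c1ccoc1)cn2[C@@H]1O[C@H](CO)[C@@H](O)[C@H]1O` gives 98800 nM in this assay, a number that sits within the scatter of that of compound 3, so the two cannot be placed in order. Compound 1 `CN(C)c1ncnc2c1c(-c1ccsc1)cn2[C@@H]1O[C@H](CO)[C@@H](O)[C@H]1O` reaches only the limit of this assay, reported as > 100000 nM. The single measured step among these three, an at least 1.0-fold lower number from compound 1 to compound 3 (0.01 log units; that floor lies within the scatter), starts from the limit of > 100000 nM in this assay, at which 1 of the 3 values shown sits, and therefore says nothing firm about how a change at this place moves the number.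

Compound 4 `CSc1ncnc2c1c(-c1ccsc1)cn2[C@@H]1O[C@H](CO)[C@@H](O)[C@H]1O` is the next member and differs from compound 3 in one place: methylsulfanyl in place of methyl on an aromatic carbon. Within the data shown here, no measured step covers this exact exchange. Compound 2 also carries a methylsulfanyl but differs from compound 3 elsewhere as well, and its value and that of compound 3 lie within the scatter of each other. Among the measured compounds shown here, the one step at the same place, an at least 1.0-fold lower number from compound 1 to compound 3 (0.01 log units; that floor lies within the scatter), likewise stays within the scatter. No shift beyond the scatter is therefore expected in this assay. The estimate for compound 4 is 97000 nM, with a range from 40000 nM to 200000 nM. The expected step of a 1.0-fold higher number from compound 3 to compound 4 (0.00 log units; within the scatter) is accordingly small.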

Compound 4, half-maximal inhibitory concentration: 95800 nM
Estimate against measurement, compound 4: 1.0-fold (0.01 log units) above; the measured number falls inside the stated range.
By their numbers in this assay, from the lowest: compounds 4, 3 and 2 (each within the scatter of the next). At a limit, above all of these: compound 1.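

Among these compounds, compound 4 gives the direct reading of this exchange that the earlier compounds lacked: in this assay methylsulfanyl in place of methyl on an aromatic carbon gives a 1.0-fold lower number from compound 3 to compound 4 (0.00 log units; within the scatter) and the two groups therefore cannot be told apart at this place on the thiophen-3-yl compounds. It also isolates the second point of difference, with thiophen-3-yl in place of furan-3-yl on an aromatic carbon giving a 1.0-fold lower number from compound 2 to compound 4 (0.01 log units; within the scatter) and this exchange likewise shows no separation when methylsulfanyl is held constant. The step of an at least 1.0-fold lower number from compound 1 to compound 4 (0.01 log units; that floor lies within the scatter) cannot be read, because compound 1 stands at a limit of the assay: the limit of > 100000 nM in this assay, at which 1 of the 4 values shown sits.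

Among compounds 2, 3 and 4, no measured number stands beyond the scatter of another, so in this assay these compounds do not show any change that moves the number. On these data alone, it remains open whether a primary amine, a longer chain such as ethylsulfanyl, or a carboxylic acid at this place on the six-membered aromatic ring would leave the number where it is, and whether any other ring in place of thiophen-3-yl or furan-3-yl would do the same.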